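Adding a Cyano Group to an Inactive Series

A few compounds are considered here, and "the series" means these few. Any claim that something is new, unique, unknown or untested is made for them only; others in the source may bear on it.

Measured compounds and their values:
Compound 1, `COc1ccc2c(c1)c(-c1cc(C(F)(F)F)c(C#N)c(-c3cn(S(=O)(=O)c4ccc(C)cc4)c4ccc(OC)cc34)n1)cn2S(=O)(=O)c1ccc(C)cc1`, in a functional assay on A549 cells (Homo sapiens) for cytotoxicity; a lower number here means a stronger inhibitor, a higher number a weaker inhibitor: > 100000 nM, which is a limit of the assay.
Compound 2, `COc1ccc2c(-c3cc(C(F)(F)F)c(C#N)c(-c4cn(S(=O)(=O)c5ccc(C)cc5)c5cc(OC)ccc45)n3)cn(S(=O)(=O)c3ccc(C)cc3)c2c1`, in this assay: > 100000 nM, a limit of the assay.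
Compound 3, `Cc1ccc(S(=O)(=O)n2cc(-c3cc(C(F)(F)F)cc(-c4cn(S(=O)(=O)c5ccc(C)cc5)c5cc(Br)ccc45)n3)c3ccc(Br)cc32)cc1`, in this assay: > 100000 nM, a limit of the assay.

For the measured compounds named here, compound 3 stands where every value so far stands: at the limit of > 100000 nM in this assay, at which 3 of the 3 values shown sit, so no number is known for it, only that it lies beyond the reach of the test. Compound 4, `Cc1ccc(S(=O)(=O)n2cc(-c3cc(C(F)(F)F)c(C#N)c(-c4cn(S(=O)(=O)c5ccc(C)cc5)c5cc(Br)ccc45)n3)c3ccc(Br)cc32)cc1`, differs from compound 3 in one place: cyano in place of hydrogen on an aromatic carbon. Going by the values given here, no measured pair shows this change directly. Compounds 1 and 2 already carry the cyano and give only limits, so the change is expected to bring nothing beyond the scatter, a step of a number no higher from compound 3 to compound 4 (the limit leaves the size open) in this assay. Compound 4 is therefore expected to give about 100000 nM, within 30000 nM to 300000 nM, most likely reported as a limit again.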

Compound 4, half-maximal inhibitory concentration: > 100000 nM
Compound 4 gave a limit, no number; the forecaster's own chance of this, stated with the estimate: 85%; the middle value sits exactly at the limit.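

Compound 3 and compound 4 both give only a limit, so no step can be read between them: the limit of > 100000 nM in this assay, at which 4 of the 4 values shown sit.

The compounds shown leave open what cyano in place of hydrogen does in this assay, and which change to the shared core would yield a number there.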